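The source may report more compounds than this note shows. Statements on the series, on what has been measured and on what is new or still open speak of the compounds shown alone.

Three analogues sharing one core have been measured in a functional assay, with a stated time of 6 min; on this read-out lower numbers stand for stronger inhibition and higher numbers for weaker inhibition. Compound 1 `Fc1cccc(NCn2nc(-c3ccc4c(c3)OCCO4)oc2=S)c1` gives 6620 nM; compound 2 `S=c1oc(-c2ccc3c(c2)OCCO3)nn1CNc1ccccc1Cl` gives 7230 nM; compound 3 `S=c1oc(-c2ccc3c(c2)OCCO3)nn1CNc1cccc(Br)c1` gives 10800 nM. Compound 1 carries the lowest of the three numbers, though the gap to compound 2 a 1.1-fold higher number from compound 1 to compound 2 (0.04 log units; within the scatter) and the gap to compound 3 a 1.6-fold higher number from compound 1 to compound 3 (0.21 log units; within the scatter) both sit within the scatter, as does a 1.5-fold higher number from compound 2 to compound 3 (0.17 log units; within the scatter). Compound 4 `O=[N+]([O-])c1ccccc1NCn1nc(-c2ccc3c(c2)OCCO3)oc1=S` is not yet measured; it differs from compound 1 by 2-nitrophenyl in place of 3-fluorophenyl on an amine nitrogen. Within the data shown here, the closest precedent is the exchange on the same amine nitrogen from compound 1 to compound 2, which moved nothing beyond the scatter, so no shift beyond the scatter is expected in this assay. Compound 4 is therefore estimated at 7000 nM, range 3000 nM to 16000 nM, an expected step of a 1.1-fold higher number from compound 1 to compound 4 (0.02 log units; within the scatter).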

Compound 4, half-maximal inhibitory concentration: 10900 nM
Beside the measured number, compound 4's estimate is 1.6-fold (0.19 log units) below it; the range from low to high includes it.
By their numbers in this assay, from the lowest: compounds 1, 2, 3 and 4 (each within the scatter of the next).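

In this assay, the 2-nitrophenyl group on the amine nitrogen stays within the scatter of all three halogenated phenyl groups (a 1.6-fold higher number from compound 1 to compound 4 (0.22 log units; within the scatter); a 1.5-fold higher number from compound 2 to compound 4 (0.18 log units; within the scatter); a 1.0-fold higher number from compound 3 to compound 4 (0.00 log units; within the scatter)). Among these compounds, the series so far held only halogens on this phenyl ring, and a nitro group now also produces no step beyond the scatter, so the four compounds cannot be ranked. Nothing available bears on the reason for this flat result.

From the compounds shown here alone, whether an amine or a carboxylic acid on the phenyl ring would produce a step beyond the scatter remains open. So does the effect of replacing the phenyl group with a saturated ring or a longer chain.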